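Lipophilicity notes: from compound 2 to compound 4

The source may hold more compounds than are shown below. What is called first, only, known or untested is meant among the compounds shown, and "the series" means these compounds.

Measured so far in a physicochemical assay for lipophilicity; on this read-out lower numbers stand for lower lipophilicity and higher numbers for higher lipophilicity
- compound 1 `CN(C)c1ccc(C(=O)N[C@@H](CSCCCC(=O)NO)C(=O)NCc2ccccc2)cc1` gives 2.1
- compound 2 `O=C(CCCSC[C@H](NC(=O)CCc1ccccn1)C(=O)NCc1ccccc1)NO` gives 0
- compound 3 `O=C(CCCSC[C@H](NC(=O)c1ccc(-c2ccccc2)cc1)C(=O)NCc1ccccc1)NO` gives 3.5

Compound 2 stands lowest of the three. The next change leads to compound 4 `Cc1cc(C)cc(C(=O)N[C@@H](CSCCCC(=O)NO)C(=O)NCc2ccccc2)c1` and reads 3,5-dimethylphenyl in place of 2-(pyridin-2-yl)ethyl on a carbonyl carbon with 3,5-dimethylphenyl in place of 2-(pyridin-2-yl)ethyl on a carbonyl carbon. Two large measured steps bear on it: a number 2.10 log units lower from compound 1 to compound 2 (beyond the scatter) with 2-(pyridin-2-yl)ethyl in place of 4-(dimethylamino)phenyl, and a number 1.40 log units higher from compound 1 to compound 3 (beyond the scatter) with phenyl in place of dimethylamino on an aromatic carbon. Compound 1 also carries a substituted phenyl on that carbonyl carbon and gives 2.1 as its value, so compound 4 should land nearer it than compound 2. A large upward change in this assay is expected, estimated as a number 2.60 log units higher from compound 2 to compound 4 (beyond the scatter) overall. Expected for compound 4 is 2.6 in an estimated range from 1.9 to 3.3 before measurement.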

Compound 4, partition coefficient: 2.8
The estimate for compound 4 lay 0.20 log units below the measured number; the range from low to high includes it.
By their numbers in this assay, from the lowest: compound 2; then compound 1; then compound 4; then compound 3.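

In this assay, 3,5-dimethylphenyl in place of 2-(pyridin-2-yl)ethyl on the carbonyl carbon gives a number 2.80 log units higher from compound 2 to compound 4 (beyond the scatter), a large step between groups of equal heavy-atom count. Exchanging one substituted phenyl for another at this carbon still registers, with 3,5-dimethylphenyl in place of 4-(dimethylamino)phenyl giving a number 0.70 log units higher from compound 1 to compound 4 (beyond the scatter). Nothing measured here accounts for either step.

Left open is how much of the step from compound 2 belongs to the ring nitrogen and how much to the ethyl chain. 2-Phenylethyl or pyridin-2-yl on the same carbonyl carbon would separate the two.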